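A few compounds are considered here, and "the series" means these few. Any claim that something is new, unique, unknown or untested is made for them only; others in the source may bear on it.

Compound 1, `COC(=O)c1sc2cc(-c3ccc(C#N)cc3)cnc2c1N`, gives > 75000 nM in a functional assay on A-375 cells (Homo sapiens) for inhibition, read by sulforhodamine B assay, with a stated time of 48 h (on this read-out higher numbers stand for weaker inhibition of growth and lower numbers for stronger inhibition of growth), a limit of the assay rather than a number.
Compound 2, `COC(=O)c1sc2cc(-c3ccc(C(F)(F)F)cc3)cnc2c1N`, gives > 150000 nM in this assay, again a limit rather than a number.

Compound 2 therefore stands at the upper edge of what this assay reports, and compound 1 stands at a limit as well, so neither has a measured number within the range of the assay. Among the measured compounds shown here, the one step between measured compounds, a step that the two limits leave unreadable from compound 1 to compound 2, cannot be given a size because both of its ends sit at limits, namely the limit of > 75000 nM in this assay, at which 1 of the 2 values shown sits, and (the limit of > 150000 nM in this assay, at which 1 of the 2 values shown sits).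

Compound 3, `COC(=O)c1sc2cc(-c3ccc(OC)cc3)cnc2c1N`, differs from compound 2 in one place: methoxy in place of trifluoromethyl on an aromatic carbon. For the measured compounds named here, the only measured step that touches this position, a step that the two limits leave unreadable from compound 1 to compound 2, concerns a different pair of groups and yields no readable size, so no direction beyond the scatter can be expected from the data in hand. Given that compound 2 sits at a limit, compound 3 is expected to sit likewise at or near a limit of this assay, estimated at 100000 nM with a range from 20000 nM to 500000 nM, which corresponds to an expected step of an at least 1.5-fold lower number from compound 2 to compound 3 (0.17 log units; that floor lies within the scatter).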

Compound 3, concentration for 50% growth inhibition: > 150000 nM
Compound 3: no number, only a limit; the forecaster's own chance of this, stated with the estimate: 75%; middle value at least 1.5-fold (0.17 log units) from the limit.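

Compound 3 gives only a limit in this assay, so its steps from compound 1 and from compound 2 cannot be read. The compounds shown leave open whether cyano, trifluoromethyl and methoxy differ at all in their effect on growth, and none of the three compounds has a measured number.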